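Adding a second hydroxymethyl to the pyrrole core

The source may hold more compounds than are shown below. What is called first, only, known or untested is meant among the compounds shown, and "the series" means these compounds.

Measured so far:
compound 1 `COC(=O)c1cc2n(c1C)[C@@H](c1ccccc1)SC2`, 48800 nM in a functional assay on MCF7 cells (Homo sapiens) for cytotoxicity, read by MTT assay, with a stated time of 72 h; on this read-out higher numbers stand for weaker inhibition and lower numbers for stronger inhibition
compound 2 `Cc1c(CO)cc2n1[C@@H](c1ccccc1)SC2`, 2400 nM
compound 3 `Cc1cc(CO)c2n1[C@@H](c1ccccc1)SC2`, 29900 nM

Compound 3 gives the second highest number of the three, close to compound 1 and well above compound 2. Compound 4 `Cc1c(CO)c(CO)c2n1[C@@H](c1ccccc1)SC2` differs from compound 3 by hydroxymethyl in place of hydrogen on an aromatic carbon. Within the data shown here, no measured step replaces hydrogen by hydroxymethyl; the only related step, a 20-fold lower number from compound 1 to compound 2 (1.31 log units; beyond the scatter), concerns a different exchange and bears on the question only loosely. Compound 2, which carries its hydroxymethyl where the new group enters, gives a far lower number than compound 3. Compound 4 is therefore expected to move toward compound 2, a step of a 5.0-fold lower number from compound 3 to compound 4 (0.70 log units; beyond the scatter), with an estimated value of 6000 nM (range 1500 nM to 30000 nM).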

Compound 4, half-maximal inhibitory concentration: 1000 nM
Compound 4: the middle estimate sits 6.0-fold (0.78 log units) above what was measured, outside the stated range (below it).
By their numbers in this assay, from the lowest: compound 4; then compound 2; then compounds 3 and 1 (each within the scatter of the next).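

In this assay, hydroxymethyl in place of hydrogen on an aromatic carbon lowers the number in both available comparisons, with a 30-fold lower number from compound 3 to compound 4 (1.48 log units; beyond the scatter) and a 2.4-fold lower number from compound 2 to compound 4 (0.38 log units; beyond the scatter). The second step is the smaller, although it is still beyond the scatter, so the size of this change depends on which hydroxymethyl the compound already carries. Compound 4, with both groups, thus gives a lower number than either compound with one.

No evidence is available to explain the difference in step size. Going by these compounds, whether an amine or a carboxylic acid could take the place of either hydroxymethyl and keep such a low number remains open.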